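Nitro to fluoro on the aryl arm of compound 2

The source may hold more compounds than are shown below. What is called first, only, known or untested is meant among the compounds shown, and "the series" means these compounds.

Compound 2 `COc1ccc(S(=O)(=O)N2CCc3cccc(NS(=O)(=O)c4ccc([N+](=O)[O-])cc4)c32)cc1` sits at the weak end of the three values measured in a functional assay on MKN-45 cells (Homo sapiens) for cytotoxicity; a higher number here means a weaker inhibitor, a lower number a stronger inhibitor: compound 2 gives 933 nM, whereas compound 1 `COc1ccc(S(=O)(=O)N2CCc3cccc(NC(=O)c4ccc(C#N)cc4)c32)cc1` gives 89 nM and compound 3 `COc1ccc(S(=O)(=O)N2CCc3cc(Br)cc(NC(=O)c4ccncc4)c32)cc1` gives 86 nM, both gaps beyond the scatter, so compound 2 is the weakest of the three. Compound 4 `COc1ccc(S(=O)(=O)N2CCc3cccc(NS(=O)(=O)c4ccc(F)cc4)c32)cc1` keeps the rest of compound 2 and changes one group: fluoro in place of nitro on an aromatic carbon. Within the data shown here, no measured pair isolates this change; compounds 1 and 3 differ from compound 2 in other places as well, so they do not show what the nitro group contributes. The step from compound 2 to compound 4 is expected to be small, likely within the scatter, with a slight lean toward a lower number. Compound 4 is estimated at 700 nM, range 250 nM to 2500 nM. This corresponds to an expected step of a 1.3-fold lower number from compound 2 to compound 4 (0.12 log units; within the scatter).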

Compound 4, half-maximal inhibitory concentration: 890 nM
For compound 4 the middle estimate is 1.3-fold (0.10 log units) below the measured one; measured number inside the range.
By their numbers in this assay, from the lowest: compounds 3 and 1 (each within the scatter of the next); then compounds 4 and 2 (each within the scatter of the next).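

In this assay, a 1.0-fold lower number from compound 2 to compound 4 (0.02 log units; within the scatter) shows that 4-fluorophenyl and 4-nitrophenyl cannot be told apart on this sulfonyl arm, so the nitro group is not what separates compound 2 from the lower numbers. With a 10-fold higher number from compound 1 to compound 4 (1.00 log units; beyond the scatter) as the step for (4-fluorophenyl)sulfonyl in place of (4-cyanophenyl)carbonyl on the nitrogen, the gap follows that combined swap, which changes the link and the aryl group together. No supporting data explain either step. Still open, from the compounds shown here alone, is whether a 4-fluorophenyl carbonyl alone recovers the lower number, and whether an amine or a carboxylic acid on this aromatic carbon moves the sulfonyl series at all.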